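Branching the Carbamate Chain of a Selenocyanate Series

This account rests on a few compounds, and the source may have more. Where it says the series, first, only, none or still open, it means among the compounds named here.

Three carbamates built on the same core have been tested in a functional assay on PC-3 cells (Homo sapiens) for cytotoxicity, read by MTT assay, with a stated time of 72 h; on this read-out lower numbers stand for stronger inhibition of growth and higher numbers for weaker inhibition of growth. Compound 1, `COc1ccc(OC(=O)Nc2ccc([Se]C#N)cc2)cc1`, gives 7500 nM. Compound 2, `CCCOC(=O)Nc1ccc([Se]C#N)cc1`, gives 21100 nM, and compound 3, `CCCCOC(=O)Nc1ccc([Se]C#N)cc1`, gives 12400 nM. Compound 3 thus sits within the usual scatter of both neighbours: its number differs from that of compound 1 and from that of compound 2 by amounts that repeated measurements of this kind routinely produce, so no ranking among the three can be claimed.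

Compound 4, `CC(C)COC(=O)Nc1ccc([Se]C#N)cc1`, differs from compound 3 only in the shape of the chain: isopropyl in place of propyl on a saturated chain carbon bound to an oxygen next to a carbonyl group. Among the compounds with values here, only one measured step bears on this kind of chain change, the lengthening by one carbon that gave a 1.7-fold lower number from compound 2 to compound 3 (0.23 log units; within the scatter). Since that change left the number within the scatter, no movement beyond the scatter is expected in this assay for a rearrangement of the same three carbons either. The estimated step is a 1.0-fold lower number from compound 3 to compound 4 (0.01 log units; within the scatter). Compound 4 is therefore expected to give about 12000 nM, with a range from 6000 nM to 25000 nM.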

Compound 4, concentration for 50% growth inhibition: 21600 nM
The estimate for compound 4 lay 1.8-fold (0.26 log units) below the measured number; low and high end bracket the measured number.
By their numbers in this assay, from the lowest: compounds 1, 3, 2 and 4 (each within the scatter of the next, the first and the last beyond it).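

In this assay, isopropyl in place of propyl on a saturated chain carbon bound to an oxygen next to a carbonyl group gives a 1.7-fold higher number from compound 3 to compound 4 (0.24 log units; within the scatter), so a change in the shape of the chain, with the same atoms, also stays inside the usual scatter at this position. Methyl in place of hydrogen on a saturated chain carbon bound to two saturated chain carbons gives a 1.0-fold higher number from compound 2 to compound 4 (0.01 log units; within the scatter), so adding this branch to the chain of compound 2 likewise produces no step beyond the scatter. No measurement at hand explains either step.

Compound 2, compound 3 and compound 4 all lie within the scatter of one another, so these chains do not show whether any group at this position can move the number beyond it. A longer chain, or a chain ending in an amine, remains an open case.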